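A Methyl Added to a Series That Stays at Its Limits

The source may hold more compounds than are shown below. What is called first, only, known or untested is meant among the compounds shown, and "the series" means these compounds.

Compound 1 `CC(C)(C)NCc1c(C(=O)O)nn(-c2ccccc2)c1-c1ccccc1`, compound 2 `Cc1ccc(-c2c(CNC(C)(C)C)c(C(=O)O)nn2-c2ccccc2)cc1` and compound 3 `CC(C)(C)NCc1c(C(=O)O)nn(-c2ccc(Cl)cc2)c1-c1ccccc1` share one core and differ only in a single ring substituent. In a functional assay on K562 cells (Homo sapiens) for inhibition, read by sulforhodamine B assay, with a stated time of 48 h (a higher number here means a weaker inhibitor of growth, a lower number a stronger inhibitor of growth), compound 1 gives only a limit, > 716000 nM. Compound 2 likewise reaches only a limit in this assay, namely > 688000 nM. For compound 3 the result in this assay is again a limit, > 652000 nM. Each of the three therefore sits at its own limit (the limit of > 716000 nM in this assay, at which 1 of the 3 values shown sits, (the limit of > 688000 nM in this assay, at which 1 of the 3 values shown sits), (the limit of > 652000 nM in this assay, at which 1 of the 3 values shown sits)), so the step that the two limits leave unreadable from compound 1 to compound 2, made by methyl in place of hydrogen on an aromatic carbon, cannot be sized, and neither can a step that the two limits leave unreadable from compound 1 to compound 3, which arises from chloro in place of hydrogen on an aromatic carbon. Compound 4 `Cc1ccc(-c2c(CNC(C)(C)C)c(C(=O)O)nn2-c2ccc(Cl)cc2)cc1` is not yet measured; it differs from compound 3 by methyl in place of hydrogen on an aromatic carbon, the same change that separates compound 2 from compound 1, set here on the core of compound 3 rather than on that of compound 1. Resting on a step that the two limits leave unreadable from compound 1 to compound 2, compound 4 is expected to remain at a limit as well, with an expected step that the limit leaves unreadable from compound 3 to compound 4 near nothing. The estimate for compound 4 in this assay is 700000 nM, between 250000 nM and 2000000 nM.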

Compound 4, concentration for 50% growth inhibition: > 629000 nM
Compound 4: no number, only a limit; the forecaster's own chance of this, stated with the estimate: 85%; the middle value does not contradict the limit.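

In this assay compound 4 gives only a limit, > 629000 nM. Its steps from compound 3 and from compound 2 therefore cannot be read. The compounds shown leave open whether methyl or chloro in place of hydrogen changes growth inhibition at all, and how strong an inhibitor on the shared core would be.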